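A few compounds are considered here, and "the series" means these few. Any claim that something is new, unique, unknown or untested is made for them only; others in the source may bear on it.

For the measured compounds named here, compound 2 `C[C@@H]1CN(c2sc(CO)nc2-c2nc3ccccc3[nH]2)CCN1C(=O)Cn1cnc2cccnc21` gives 3380 nM in an assay on blood for inhibition of C-X-C chemokine receptor type 3 (Homo sapiens), with a stated time of 30 min (on this read-out lower numbers stand for stronger inhibition and higher numbers for weaker inhibition), the higher of the two numbers measured so far, while compound 1 `C[C@@H]1CN(c2scnc2-c2nc3ccccc3[nH]2)CCN1C(=O)Cn1cnc2cccnc21` gives 554 nM. Going by the values given here, the single known step, a 6.1-fold higher number from compound 1 to compound 2 (0.79 log units; beyond the scatter), came from hydroxymethyl in place of hydrogen on an aromatic carbon. Compound 3 `C[C@@H]1CN(c2sc(CN(C)C)nc2-c2nc3ccccc3[nH]2)CCN1C(=O)Cn1cnc2cccnc21` differs from compound 2 by dimethylamino in place of hydroxy on a saturated chain carbon bound to an aromatic carbon. Among the compounds with values here, no measured step exchanges hydroxy for dimethylamino, so the known step shows only how far this part of the shared core can move the number. Compound 3 is expected to give 2000 nM, within 600 nM to 7000 nM. That estimate means a 1.7-fold lower number from compound 2 to compound 3 (0.23 log units; within the scatter).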

Compound 3, half-maximal inhibitory concentration: 1150 nM
Estimate against measurement, compound 3: 1.7-fold (0.24 log units) above, within the range that was stated.
By their numbers in this assay, from the lowest: compound 1; then compound 3; then compound 2.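

The group on this saturated chain carbon clearly affects the result: in this assay, dimethylamino in place of hydroxy gives a 2.9-fold lower number from compound 2 to compound 3 (0.47 log units; beyond the scatter) and so takes back part of the rise seen with hydroxymethyl. Yet (dimethylamino)methyl in place of hydrogen on the aromatic carbon still gives a 2.1-fold higher number from compound 1 to compound 3 (0.32 log units; beyond the scatter) and thus does not match the unsubstituted compound. No measured evidence here explains either shift.

As far as these compounds go, whether a longer chain, a cyclic amine such as morpholine, or a carboxylic acid at this place could bring the number below that of compound 1 remains open.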